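The source may report more compounds than this note shows. Statements on the series, on what has been measured and on what is new or still open speak of the compounds shown alone.

Compound 1 `COc1ccc(-c2nc3cc(Cl)c(Cl)cc3[nH]2)c(N)c1` was examined in an ADME assay on Vero cells (Chlorocebus sabaeus) for cytotoxicity; on this read-out higher numbers stand for lower toxicity in this test and lower numbers for higher toxicity in this test. In this assay, going by the values given here, compound 1 gives 75000 nM, and this is the only plain number in the set. The two remaining values are limits of the assay rather than numbers. Compound 2 `CC(=O)Nc1ccc(-c2nc3ccccc3[nH]2)cc1` reaches such a limit: in this assay compound 2 gives > 100000 nM. Compound 3 `CCC(=O)Nc1ccc(-c2nc3ccccc3[nH]2)cc1` does the same: in this assay compound 3 gives > 100000 nM. Among the compounds with values here, the only step between two measured compounds that differ in one place, a step that the two limits leave unreadable from compound 2 to compound 3, cannot be read because the limit of > 100000 nM in this assay, at which 2 of the 3 values shown sit, covers both of its ends, so nothing is known about how large it was or which way it went.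

Compound 4 `COc1ccc(-c2nc3cc(Cl)c(Cl)cc3[nH]2)c([N+](=O)[O-])c1` differs from compound 1 in a single place (nitro in place of amino on an aromatic carbon). Within the data shown here, no measured step involves a nitro group, an amino group, or the ring that carries them, so there is no measured step that bears on this change at all. With nothing to point either way, the step from compound 1 to compound 4 is expected to stay within the usual scatter, which means no change at the digits printed from compound 1 to compound 4 (within the scatter). Compound 4 is therefore estimated at 75000 nM, with a range from 30000 nM to 150000 nM, and with a real chance that the assay again reports only a limit.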

Compound 4, half-maximal cytotoxic concentration: 80000 nM
For compound 4 the middle estimate is 1.1-fold (0.03 log units) below the measured one; the measured number falls inside the stated range.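

Replacing amino with nitro on this aromatic carbon, ortho to a large group and meta to a methoxy group, gives a 1.1-fold higher number from compound 1 to compound 4 (0.03 log units; within the scatter) in this assay. This is a sizeable exchange in the structure, with 3 heavy atoms entering where 1 leaves and 0 hydrogen-bond donors where there was 1, yet in this pair it does not move the read-out beyond the scatter. It is also the first step in the set that can be read, as the only earlier step stays unreadable because both of its ends sit at a limit: the limit of > 100000 nM in this assay, at which 2 of the 4 values shown sit.

This single pair cannot show whether the position tolerates every change, so a hydroxyl, a carboxylic acid or a longer chain on the same carbon could still behave differently in this assay. It also leaves open whether the exchange of amino for nitro would give the same result on a core without the two chlorines, or with the methoxy group replaced by another group such as an ethoxy group.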